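The source may hold more compounds than are shown below. What is called first, only, known or untested is meant among the compounds shown, and "the series" means these compounds.

Compound 1 `Cc1cc(NC(=O)Nc2ccc(C)c(Cl)c2)c2ccccc2n1` was tested in an ADME assay on HEK293 cells (Homo sapiens) for cytotoxicity, with a stated time of 72 h; a lower number here means that less compound is needed, a higher number that more compound is needed for the effect. In this assay compound 1 gives only a limit, > 25000 nM, rather than a number. The other measured compound, compound 2 `COC(=O)c1ccc(NC(=O)Nc2cc(C)nc3ccccc23)cc1`, gives 15000 nM in this assay. Compound 1 thus sits at the limit of > 25000 nM in this assay, at which 1 of the 2 values shown sits. Compound 3 `Cc1cc(NC(=O)Nc2cccc(Cl)c2)c2ccccc2n1` is not yet measured; it differs from compound 1 by hydrogen in place of methyl on an aromatic carbon. For the measured compounds named here, no measured pair shares this change, so the step from compound 1 to compound 3 in this assay is expected to be small, a number no higher from compound 1 to compound 3 (the limit leaves the size open), within the usual scatter. Compound 3 is therefore estimated at 25000 nM, with a likely range from 10000 nM to 60000 nM.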

Compound 3, half-maximal effective concentration: 21000 nM
Estimate against measurement, compound 3: 1.2-fold (0.08 log units) above; measured number inside the range.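

Exchanging the methyl for hydrogen on this aromatic carbon, ortho to a chloro group, gives an at least 1.1-fold lower number from compound 1 to compound 3 (0.07 log units; that floor lies within the scatter) in this assay. For the compounds shown here, this is the first reading at this position: without the methyl, compound 3 gives a real number, whereas compound 1 gives only a limit. The true size of the step stays open, and only its floor can be read: the limit of > 25000 nM in this assay, at which 1 of the 3 values shown sits.

The compounds shown leave open how a different group on this carbon, such as an amine or a longer chain, would shift the number. They also leave open whether such a shift would exceed the usual scatter.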